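Isopropyl branching on the ester-bearing carbon of compound 2

The compounds below may be only part of what the source reports. "The series", "measured", "known", "first", "only" and "open" are said of these compounds alone.

Compound 2 `COC(=O)[C@@H](C)NC(=O)Cn1cc(C2=C(c3c[nH]c4ccccc34)C(=O)N(C)C2=O)c2ccccc21` is the point of departure. In a functional assay on HCT-8 cells (Homo sapiens) for cytotoxicity, read by MTT assay, with a stated time of 24 h (on this read-out higher numbers stand for weaker inhibition and lower numbers for stronger inhibition), compound 2 gives 21400 nM, the lowest of the two numbers recorded, with compound 3 nearest. Compound 3 `COC(=O)CCNC(=O)Cn1cc(C2=C(c3c[nH]c4ccccc34)C(=O)N(C)C2=O)c2ccccc21` gives 50900 nM in this assay. Compound 1 `CC[C@H](C)[C@@H](NC(=O)Cn1cc(C2=C(c3c[nH]c4ccccc34)C(=O)N(C)C2=O)c2ccccc21)C(=O)OC` reaches only the limit of this assay, recorded as > 100000 nM, and that limit is the limit of > 100000 nM in this assay, at which 1 of the 3 values shown sits.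

Compound 4 `COC(=O)[C@H](NC(=O)Cn1cc(C2=C(c3c[nH]c4ccccc34)C(=O)N(C)C2=O)c2ccccc21)C(C)C` differs from compound 2 in one place: isopropyl in place of methyl on a saturated chain carbon bound to an amide-type nitrogen and a carbonyl carbon. Among the measured compounds shown here, two measured steps bear on this. The closest is an at least 4.6-fold lower number from compound 1 to compound 2 (0.66 log units; beyond the scatter), where the branched sec-butyl was replaced by methyl; read in reverse, adding branching at this carbon raised the number. The step of a 2.4-fold higher number from compound 2 to compound 3 (0.38 log units; beyond the scatter) shows that even a shift of the ester within the chain changes the number modestly, while an at least 1.9-fold lower number from compound 1 to compound 3 (0.29 log units; that floor lies within the scatter) has a floor within the scatter. Since isopropyl sits between methyl and sec-butyl in size, a rise in the number is expected, though perhaps not to the limit reached by compound 1.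

Compound 4 is therefore expected to give about 60000 nM in this assay, within 25000 nM to 150000 nM. That estimate corresponds to the step of a 2.8-fold higher number from compound 2 to compound 4 (0.45 log units; beyond the scatter).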

Compound 4, half-maximal inhibitory concentration: 25800 nM
Compound 4: middle estimate off by 2.3-fold (0.37 log units), on the high side, and the stated range covers the measured number.
By their numbers in this assay, from the lowest: compounds 2, 4 and 3 (each within the scatter of the next, the first and the last beyond it). At a limit, above all of these: compound 1.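

In this assay, the change from methyl to isopropyl on the saturated chain carbon bound to an amide-type nitrogen and a carbonyl carbon gives a 1.2-fold higher number from compound 2 to compound 4 (0.08 log units; within the scatter), and the comparison with the unbranched 2-(methoxycarbonyl)ethyl chain gives a 2.0-fold lower number from compound 3 to compound 4 (0.30 log units; within the scatter), so branching at this carbon does not by itself separate compound 4 from either compound. The clear step lies one carbon further out, where hydrogen in place of methyl, three bonds along the chain from an amide-type nitrogen and a carbonyl carbon, gives an at least 3.8-fold lower number from compound 1 to compound 4 (0.58 log units; beyond the scatter), so among these compounds the loss of effect appears only with the 1-(methoxycarbonyl)-2-methylbutyl group of compound 1 and not with the smaller isopropyl branch. Compound 1 gives no number here, only a limit: the limit of > 100000 nM in this assay, at which 1 of the 4 values shown sits.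

The compounds shown leave open how a tert-butyl or a benzyl group on this same carbon would read, and so where between isopropyl and the larger group the step sets in. They also leave open whether a carboxylic acid in place of the methyl ester would keep these branched compounds in the same range.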